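From compound 3 to the unmeasured compound 4

The source may report more compounds than this note shows. Statements on the series, on what has been measured and on what is new or still open speak of the compounds shown alone.

Measured in a functional assay on K562 cells (Homo sapiens) for inhibition, with a stated time of 72 h; on this read-out higher numbers stand for weaker inhibition and lower numbers for stronger inhibition:
Compound 1 `NC1CCC(Nc2nc(NCc3ccc(Br)cc3)c3ncn(C4CCCC4)c3n2)CC1` gives 1170 nM
Compound 2 `NC1CCC(Nc2nc(NCc3ccc(-c4ccsc4)cc3)c3ncn(C4CCCC4)c3n2)CC1` gives 150 nM
Compound 3 `NC1CCC(Nc2nc(NCc3ccc(-c4ccsc4)nc3)c3ncn(C4CCCC4)c3n2)CC1` gives 150 nM

Compound 3 holds the lowest number of the three, shared with one other (no change at the digits printed from compound 2 to compound 3 (within the scatter)). The remaining compound lies well apart (a 7.8-fold lower number from compound 1 to compound 3 (0.89 log units; beyond the scatter)).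

Compound 4 `NC1CCC(Nc2nc(NCc3cc(Cl)ccc3O)c3ncn(C4CCCC4)c3n2)CC1` has not yet been measured. It carries 5-chloro-2-hydroxyphenyl in place of 6-(thiophen-3-yl)pyridin-3-yl on a saturated chain carbon bound to a nitrogen on an aromatic ring.

Within the data shown here, no measured compound has a hydroxy group, so the evidence is indirect. Two modest steps bear on the change, both of which bring in thiophen-3-yl (a 7.8-fold lower number from compound 1 to compound 2 (0.89 log units; beyond the scatter); a 7.8-fold lower number from compound 1 to compound 3 (0.89 log units; beyond the scatter)). Compound 4 lacks that group, as does compound 1 at 1170 nM in this assay, so part of that gain is expected to be lost. The estimated step is a 3.3-fold higher number from compound 3 to compound 4 (0.52 log units; beyond the scatter) and points to a higher number, probably smaller than the gain. For compound 4 the expected value is 500 nM with an estimated range from 130 nM to 1800 nM in this assay.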

Compound 4, half-maximal inhibitory concentration: 690 nM
Estimate against measurement, compound 4: 1.4-fold (0.14 log units) below, within the range that was stated.
By their numbers in this assay, from the lowest: compounds 2 and 3 (each within the scatter of the next); then compounds 4 and 1 (each within the scatter of the next).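

In this assay, among these compounds, 5-chloro-2-hydroxyphenyl, the first group here with a hydroxy group, gives a 4.6-fold higher number from compound 3 to compound 4 (0.66 log units; beyond the scatter) and a 4.6-fold higher number from compound 2 to compound 4 (0.66 log units; beyond the scatter), so the two thiophen-3-yl compounds keep their place against a group of a different kind, not only against 4-bromophenyl. Set against 4-bromophenyl itself, the exchange gives a 1.7-fold lower number from compound 1 to compound 4 (0.23 log units; within the scatter), so at this place, on a saturated chain carbon bound to a nitrogen on an aromatic ring, these two groups without thiophen-3-yl are not told apart. Nothing measured here accounts for these steps.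

Going by these compounds, the chloro and hydroxy groups enter together in compound 4, so what each contributes on its own stays open. Also open, on these data alone, is how a methoxy group or an amine in place of that hydroxy group would read, and whether either would fare differently on a group that keeps thiophen-3-yl.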